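The source may report more compounds than this note shows. Statements on the series, on what has been measured and on what is new or still open speak of the compounds shown alone.

Measured compounds in this series:
- compound 1, `CC(C)N(CCN(C(=O)Nc1ccc(F)c(Cl)c1)C1CC[C@]2(c3cccc(C#N)c3)CC2C1)C(C)C` — 4.98 nM
- compound 2, `CC(C)N(CCN(C(=O)Nc1cccc(C#N)c1)C1CC[C@]2(c3cccc(C#N)c3)CC2C1)C(C)C` — 7.6 nM

For the measured compounds named here, in a functional assay for antagonist activity at melanin-concentrating hormone receptor 1 (Homo sapiens) (a higher number here means a weaker inhibitor, a lower number a stronger inhibitor), compound 1 gives 4.98 nM, the smaller of the two numbers so far; compound 2 gives 7.6 nM. Going by the values given here, the single step between them, a 1.5-fold higher number from compound 1 to compound 2 (0.18 log units; within the scatter), is within the scatter, so the two compounds are not separable on these data. That step concerns only the aryl on the urea nitrogen.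

Compound 3, `CCO/N=C/c1cccc([C@]23CCC(N(CCN(C(C)C)C(C)C)C(=O)Nc4ccc(F)c(Cl)c4)CC2C3)c1`, is the next candidate. Relative to compound 1 the change is a group of 5 heavy atoms (3 carbon, 1 nitrogen, 1 oxygen; no ring) in place of a group of 2 heavy atoms (1 carbon, 1 nitrogen; no ring), on an aromatic carbon of the six-membered aromatic ring attached to the core, meta to a large group. Among the compounds with values here, no measured step touches this ring; the one step known, from compound 1 to compound 2, sits elsewhere and does not bear on it. The working expectation for compound 3 in this assay is therefore a number near that of compound 1, with no shift beyond the scatter but a wide uncertainty, estimated at 8 nM with a range of 2 nM to 40 nM. Within the data shown here, the estimated step of a 1.6-fold higher number from compound 1 to compound 3 (0.21 log units; within the scatter) rests on no measured precedent.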

Compound 3, inhibition constant: 29 nM
For compound 3 the middle estimate is 3.6-fold (0.56 log units) below the measured one; low and high end bracket the measured number.
By their numbers in this assay, from the lowest: compounds 1 and 2 (each within the scatter of the next); then compound 3.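

In this assay, for the compounds shown here, replacing cyano with a group of 5 heavy atoms (3 carbon, 1 nitrogen, 1 oxygen; no ring) on an aromatic carbon of a six-membered aromatic ring of carbon only, meta to a large group, gives a 5.8-fold higher number from compound 1 to compound 3 (0.77 log units; beyond the scatter) and is the only step so far that lies beyond the scatter. This position therefore responds to the exchange in a way the aryl on the urea nitrogen has not yet shown, since the one step there, a 1.5-fold higher number from compound 1 to compound 2 (0.18 log units; within the scatter), does not separate its two compounds, yet the larger group is still compatible with a measurable number, as compound 3 gives 29 nM in the same read-out. No supporting data on hand bear on the origin of this step.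

Going by these compounds, a single replacement changes the heavy-atom count, the bond type and the acceptor count together, so which of these differences goes with the step remains open. Also open, on these data alone, are how an amine, a carboxylic acid or a longer chain on this aromatic carbon would compare with cyano, and whether the step holds with 3-cyanophenyl on the urea nitrogen.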